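Aryl amide in place of cyclobutyl amide on the shared core

The compounds below may be only part of what the source reports. "The series", "measured", "known", "first", "only" and "open" are said of these compounds alone.

Compound 3 `O=C(Nc1c(C(O)(C(F)(F)F)C(F)(F)F)ccc2ccccc12)C1CCC1` carries a cyclobutyl group on the carbonyl carbon of its amide. In a functional assay (Sus scrofa) with sulfonylurea receptors; K-ATP channels (Homo sapiens) as the target (on this read-out higher numbers stand for larger maximal responses and lower numbers for smaller maximal responses), compound 3 gives 97%. Its two neighbours share the same core: compound 1 `CCC(=O)Nc1c(C(O)(C(F)(F)F)C(F)(F)F)ccc2ccccc12`, which gives 96%, and compound 2 `C/C=C/C(=O)Nc1c(C(O)(C(F)(F)F)C(F)(F)F)ccc2ccccc12`, which gives 96%. The steps of a number 1 percentage points higher from compound 1 to compound 3 (within the scatter) and a number 1 percentage points higher from compound 2 to compound 3 (within the scatter) both stay inside the scatter, as does no change at the digits printed from compound 1 to compound 2 (within the scatter), so the three amides behave alike on this read-out.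

Compound 4 `N#Cc1cccc(C(=O)Nc2c(C(O)(C(F)(F)F)C(F)(F)F)ccc3ccccc23)c1` is not yet measured. It differs from compound 3 in one place: 3-cyanophenyl in place of cyclobutyl on a carbonyl carbon. The measured steps all swap one small carbon group for another on the same carbonyl carbon and none moved the response beyond the scatter. The present change brings in an aromatic ring with a nitrile, a larger alteration than any measured here, so the guide is weaker. The response for compound 4 is nevertheless expected to stay near the others, with a step of about a number 5 percentage points lower from compound 3 to compound 4 (within the scatter), giving an estimate of 92% within a range from 75% to 100%.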

Compound 4, largest response reached (reported as efficacy), in percent of the reference or control that the assay uses: 96%
Compound 4: the middle estimate sits 4 percentage points below what was measured, within the range that was stated.
By their numbers in this assay, from the lowest: compounds 1, 2, 4 and 3 (each within the scatter of the next).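

The carbonyl carbon of the amide tolerates more than small carbon groups in this assay. Replacing the small groups with 3-cyanophenyl gives a step of a number 1 percentage points lower from compound 3 to compound 4 (within the scatter) and a step of no change at the digits printed from compound 2 to compound 4 (within the scatter) as well as a step of no change at the digits printed from compound 1 to compound 4 (within the scatter) on this read-out. The entering group has 8 heavy atoms against the 4 of cyclobutyl, and it brings an aromatic ring, a triple bond and a hydrogen-bond acceptor, yet the maximal response cannot be told apart from that of the three smaller amides.

Going by these compounds, whether a plain phenyl ring without the nitrile, a phenyl ring carrying an amine or a carboxylic acid, or a longer chain would also stay level with these four remains open. Nothing given here accounts for why the response holds across this change.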